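The source may report more compounds than this note shows. Statements on the series, on what has been measured and on what is new or still open speak of the compounds shown alone.

In a functional assay on MCF7 cells (Homo sapiens) for antiproliferative activity, read by MTT assay, with a stated time of 48 h (a lower number here means a stronger inhibitor, a higher number a weaker inhibitor), compound 1 `FC(F)(F)c1ccc2[nH]c(-c3cn(-c4ccccc4)nc3-c3ccc(Cl)cc3)nc2c1` gives 4210 nM and compound 2 `COc1ccc(-c2nn(-c3ccccc3)cc2-c2nc3cc(Cl)ccc3[nH]2)cc1` gives 1760 nM, the lower of the two numbers, with a gap beyond the usual scatter. Compound 3 `COc1ccc(-c2nn(-c3ccccc3)cc2-c2nc3cc(C(F)(F)F)ccc3[nH]2)cc1` differs from compound 2 by having trifluoromethyl in place of chloro on an aromatic carbon. Within the data shown here, no measured pair isolates this change, since compound 1, at 4210 nM, also carries trifluoromethyl but differs in a second place. In this assay, no step beyond the scatter is therefore expected. Compound 3 is estimated at 2200 nM, with an expected range from 850 nM to 5500 nM.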

Compound 3, half-maximal inhibitory concentration: 5730 nM
Compound 3: middle estimate off by 2.6-fold (0.42 log units), on the low side, outside the stated range (above it).
By their numbers in this assay, from the lowest: compound 2; then compounds 1 and 3 (each within the scatter of the next).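

In this assay the change is now isolated: trifluoromethyl in place of chloro on the aromatic carbon gives a 3.3-fold higher number from compound 2 to compound 3 (0.51 log units; beyond the scatter), so here chloro carries the lower number and this position is not indifferent to the swap. Methoxy in place of chloro on an aromatic carbon gives a 1.4-fold higher number from compound 1 to compound 3 (0.13 log units; within the scatter), so those two compounds cannot be told apart. Nothing available explains the first step. The compounds shown leave open how an amine or a nitrile would fare at this position, and whether the step holds when chloro replaces the methoxy.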